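The source may report more compounds than this note shows. Statements on the series, on what has been measured and on what is new or still open speak of the compounds shown alone.

Three compounds with a shared core differ only in the aromatic group on an amide-type nitrogen. In a functional assay on RT-112 cells (Homo sapiens) for antiproliferative activity, read by MTT assay, with a stated time of 72 h (a lower number here means a stronger inhibitor of growth, a higher number a weaker inhibitor of growth), compound 1 `COc1cc(Nc2ncnc3c(NC(=O)Nc4ccc(C)cc4C)cccc23)cc(OC)c1` gives 1290 nM, compound 2 `COc1cc(Nc2ncnc3c(NC(=O)Nc4ccccc4Cl)cccc23)cc(OC)c1` gives 356 nM, and compound 3 `COc1cc(Nc2ncnc3c(NC(=O)Nc4cccc(Cl)c4Cl)cccc23)cc(OC)c1` gives 63.2 nM. Compound 3 therefore has the lowest number of the three and is the strongest growth inhibitor measured so far.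

Compound 4 `COc1cc(Nc2ncnc3c(NC(=O)Nc4cc(Cl)cc(Cl)c4)cccc23)cc(OC)c1` has the same atoms as compound 3, joined differently: 3,5-dichlorophenyl in place of 2,3-dichlorophenyl on an amide-type nitrogen. In short, it has 3,5-dichlorophenyl in place of 2,3-dichlorophenyl on an amide-type nitrogen.

For the measured compounds named here, two measured steps bear most directly on this change. Putting chloro in place of hydrogen on an aromatic carbon gave a 5.6-fold lower number from compound 2 to compound 3 (0.75 log units; beyond the scatter), and replacing the whole group gave a 20-fold lower number from compound 1 to compound 3 (1.31 log units; beyond the scatter). In these compounds, then, changes to this group moved the number well beyond the scatter. Going by the values given here, no measured pair keeps both chlorines and only rearranges them, so this evidence is indirect.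

Since compound 3 sits at the low end with 63.2 nM, a modest move to a higher number in this assay is expected, though with wide uncertainty. The estimated step is a 2.7-fold higher number from compound 3 to compound 4 (0.43 log units; beyond the scatter). For compound 4 the estimated value is 170 nM, with an expected range from 40 nM to 700 nM.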

Compound 4, concentration for 50% growth inhibition: 30.2 nM
Estimate against measurement, compound 4: 5.6-fold (0.75 log units) above, outside the stated range (below it).
By their numbers in this assay, from the lowest: compound 4; then compound 3; then compound 2; then compound 1.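

In this assay the step is a 2.1-fold lower number from compound 3 to compound 4 (0.32 log units; beyond the scatter), so on this ring the arrangement of the two chlorines changes the number even though no atom is added or removed. Each earlier group had a substituent at the position numbered 2 in its name, while 3,5-dichlorophenyl has none there, and the steps of a 12-fold lower number from compound 2 to compound 4 (1.07 log units; beyond the scatter) and a 43-fold lower number from compound 1 to compound 4 (1.63 log units; beyond the scatter) show that, among these four compounds, the lowest number does not depend on having a group at that position. No measurement shown here accounts for the better result with this arrangement of the chlorines.

The compounds shown leave open how much of this result needs both chlorines, since no ring carrying a single chlorine at either of the positions named in 3,5-dichlorophenyl appears among them. On these data alone, it also remains open whether the number would stay this low with methyl, methoxy or nitrile groups in place of the chlorines of 3,5-dichlorophenyl.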